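Swapping Fluoro for Trifluoromethoxy on the Fused Ring

The compounds below may be only part of what the source reports. "The series", "measured", "known", "first", "only" and "open" are said of these compounds alone.

Three compounds sharing one core were tested in an assay on isolated protein for inhibition of long-chain fatty acid transport protein 1 (Mus musculus); a lower number here means a stronger inhibitor, a higher number a weaker inhibitor. Compound 1 `CCn1c(CNc2ccccc2)nnc1SCC(=O)Nc1ccc(Cl)cc1` gives only a limit, > 10000 nM. Compound 2 `CCn1c(CNc2ccccc2)nnc1SCc1nc2cc(F)ccc2o1` gives 7800 nM, the higher of the two actual numbers, while compound 3 `CCC(=O)c1ccc2nc(CSc3nnc(CNc4ccccc4)n3CC)oc2c1` gives 1200 nM, and the gap between these two values lies beyond the usual scatter. Compound 4 `CCn1c(CNc2ccccc2)nnc1SCc1nc2cc(OC(F)(F)F)ccc2o1` is not yet measured; it differs from compound 2 by trifluoromethoxy in place of fluoro on an aromatic carbon. Within the data shown here, no measured pair shows this change, so its effect in this assay cannot be read from these compounds. Compound 4 is expected to give about 5000 nM, within 1500 nM to 15000 nM. That estimate means a step from compound 2 to compound 4 of a 1.6-fold lower number from compound 2 to compound 4 (0.19 log units; within the scatter), expected to stay within the scatter.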

Compound 4, half-maximal inhibitory concentration: 91 nM
Compound 4: the middle estimate sits 55-fold (1.74 log units) above what was measured; measured number below the stated range.
By their numbers in this assay, from the lowest: compound 4; then compound 3; then compound 2. At a limit, above all of these: compound 1.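

Within this assay, trifluoromethoxy in place of fluoro on this aromatic carbon gives an 86-fold lower number from compound 2 to compound 4 (1.93 log units; beyond the scatter) and is the first single change with a readable effect. The earlier compounds shown here offered no pair differing in one place, whereas this pair shows that the group at this position strongly affects the measured inhibition. Nothing shown explains why this change has so large an effect.

Still open, on these data alone, is how methoxy, an amine or a carboxylic acid at this position would compare. One pair also cannot show whether the same swap would have a similar effect on another core.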